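The source may report more compounds than this note shows. Statements on the series, on what has been measured and on what is new or still open speak of the compounds shown alone.

For the measured compounds named here, compound 1, `Cc1c(-c2ccc(F)cc2)cc(C(=O)NC2CCCCCC2)c(=O)n1Cc1ccc(F)cc1`, is the one member of this small set for which an assay on U-937 cells for inhibition of Fatty-acid amide hydrolase 1 (Homo sapiens), read by scintillation counting, with a stated time of 15 min (on this read-out higher numbers stand for weaker inhibition and lower numbers for stronger inhibition), returns a number: compound 1 gives 530 nM. Its two companions fare differently. Compound 2, `Cc1ccc(C(=O)NC2CCCCCC2)c(OCc2ccc(F)cc2)n1`, reaches only a limit of the assay, > 10000 nM. Compound 3, `CC(=O)N[C@@H]1[C@@H](O)[C@H](O)[C@@H](CO)O[C@H]1NC(=O)c1cc(Br)c(C)n(Cc2ccc(F)cc2)c1=O`, likewise stops at a limit, > 10000 nM. With the limit of > 10000 nM in this assay, at which 2 of the 3 values shown sit, compound 1 therefore stands alone as the single measured figure, and nothing among the three allows a step between measured compounds to be drawn.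

Compound 4, `Cc1c(-c2ccccc2)cc(C(=O)NC2CCCCCC2)c(=O)n1Cc1ccc(F)cc1`, is yet to be tested. It differs from compound 1 in one place: hydrogen in place of fluoro on an aromatic carbon, para to a large group on the six-membered aromatic ring of carbon only. Going by the values given here, no measured pair shows what such a change does here, so the expectation rests on the change itself. A single fluorine lost from the outer ring is a small alteration, and the step from compound 1 to compound 4 is expected to stay within the usual scatter, with the estimated shift being a 1.4-fold higher number from compound 1 to compound 4 (0.15 log units; within the scatter). Compound 4 is thus expected to give about 750 nM in this assay, with a likely range from 250 nM to 2500 nM.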

Compound 4, half-maximal inhibitory concentration: 560 nM
The estimate for compound 4 lay 1.3-fold (0.13 log units) above the measured number; measured number inside the range.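

For the compounds shown here, the newly measured pair gives the first step in this set between compounds that differ in one place, and in this assay replacing 4-fluorophenyl with phenyl gives a 1.1-fold higher number from compound 1 to compound 4 (0.02 log units; within the scatter). The fluoro on this aromatic carbon, para to a large group, is therefore not needed to retain the activity seen in this series, as hydrogen in its place leaves the reading within the scatter. The earlier compounds could not show this, since only one of them gave a number and the other two stopped at a limit of the assay: the limit of > 10000 nM in this assay, at which 2 of the 4 values shown sit.

The compounds shown leave open whether a larger replacement in this same place, such as a methoxy group, an amine or a carboxylic acid, would be accommodated as readily as hydrogen. They also leave open whether the fluoro on the other aromatic ring can be exchanged for hydrogen in the same way, and whether the result for this one change would hold on any other core.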